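Aryl urea swap on a shared quinazolinone-free core, one step

A few compounds are considered here, and "the series" means these few. Any claim that something is new, unique, unknown or untested is made for them only; others in the source may bear on it.

The measured compounds and their values:
- compound 1 `CCOc1ccc(NC(=O)Nn2c(CC)nc3ccccc3c2=O)cc1`: 50%
- compound 2 `CCc1nc2ccccc2c(=O)n1NC(=O)Nc1ccc(Br)cc1`: 54%
- compound 3 `O=C(Nc1ccc(Br)cc1)Nn1c(-c2ccccc2)nc2ccccc2c1=O`: 58%

In a functional assay on the whole organism (strain albino) with Mus musculus as the target, at a dose of 100 mg/kg by the intraperitoneal route (a lower number here means less inhibition, a higher number more inhibition at the dose given (going by the name of the read-out)), compound 2 gives 54%. On the numbers shown it sits second highest of three, yet its neighbours lie close on either side: a number 4 percentage points higher from compound 1 to compound 2 (within the scatter) and a number 4 percentage points higher from compound 2 to compound 3 (within the scatter), both within the scatter, so the three compounds cannot be told apart.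

Compound 4 `CCc1nc2ccccc2c(=O)n1NC(=O)Nc1cccc(C)c1` differs from compound 2 in one place: 3-methylphenyl in place of 4-bromophenyl on an amide-type nitrogen. Going by the values given here, the only step that touches the same part of the molecule is the change of the group on that aryl ring from compound 1 to compound 2, which was small. Among the compounds with values here, no measured step exchanges the whole 4-bromophenyl for a 3-methylphenyl, so the exact effect is unknown. With all three measured steps within the scatter, the expected step is a number 2 percentage points lower from compound 2 to compound 4 (within the scatter), that is, none beyond the scatter. Compound 4 is therefore expected to give about 52%, within a range of 38% to 66%.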

Compound 4, a percentage reported as inhibition, in the whole organism at one dose (the size of the read-out at that dose, not a potency): 53%
The estimate for compound 4 lay 1 percentage points below the measured number, and the stated range covers the measured number.
By their numbers in this assay, from the lowest: compounds 1, 4, 2 and 3 (each within the scatter of the next).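

In this assay, the step is a number 1 percentage points lower from compound 2 to compound 4 (within the scatter), so this nitrogen accepts a 3-methylphenyl as well as a 4-bromophenyl without the two compounds being told apart. The earlier step on this aryl ring exchanged only the bromo and ethoxy groups, whereas this one replaces the whole group, with a carbon-only group of the same heavy-atom count taking the place of the bromine-bearing one. Nothing available explains why the two compounds read alike.

Since the swap alters both the group on the ring and its printed ring position, the compounds shown cannot say what either alteration does alone. From the compounds shown here alone, it also stays open whether a phenyl ring carrying a carboxylic acid or an amine, or a longer chain in place of the ring on this nitrogen, would give a step beyond the scatter.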